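Compound 3: Hydrogen in Place of Hydroxy

A few compounds are considered here, and "the series" means these few. Any claim that something is new, unique, unknown or untested is made for them only; others in the source may bear on it.

In a functional assay for inhibition, with Homo sapiens as the target (a lower number here means a stronger inhibitor, a higher number a weaker inhibitor), compound 1 (`Cc1cc2c(cc1C(=O)N=C(N)N)S(=O)(=O)CC2(O)C(=O)c1ccccc1`) gives 157 nM and compound 2 (`Cc1cc2c(cc1C(=O)N=C(N)N)S(=O)(=O)C(C)(C)C2(C)O`) gives 102 nM, so these two numbers lie within the scatter of each other. Compound 3 (`Cc1cc2c(cc1C(=O)N=C(N)N)S(=O)(=O)C(C)(C)C2C`) differs from compound 2 by having hydrogen in place of hydroxy on a saturated ring carbon. Going by the values given here, no measured pair shows this change alone, so the expectation rests on compound 2 at 102 nM: no step beyond the scatter in this assay, in either direction. The estimated step is a 1.1-fold higher number from compound 2 to compound 3 (0.03 log units; within the scatter). The expected value for compound 3 is 110 nM, within an estimated range of 35 nM to 350 nM.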

Compound 3, half-maximal inhibitory concentration: 306 nM
Estimate against measurement, compound 3: 2.8-fold (0.44 log units) below; the measured number falls inside the stated range.
By their numbers in this assay, from the lowest: compounds 2, 1 and 3 (each within the scatter of the next, the first and the last beyond it).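

Going by these compounds alone, the change to hydrogen in place of hydroxy on a saturated ring carbon brings a 3.0-fold higher number from compound 2 to compound 3 (0.48 log units; beyond the scatter) in this assay and gives the only single-place comparison in this set. In this pair, the hydroxy goes with the lower number, which compound 1 and compound 2 could not show, as they differ in more than one place. Nothing available here bears on the cause of this step. Still open, as far as these compounds go, is how an amine or a methoxy group at this position would compare with the hydroxy, and whether the step holds on the core of compound 1.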